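Cytotoxicity notes on the shared core: compound 3 to compound 4

The source may hold more compounds than are shown below. What is called first, only, known or untested is meant among the compounds shown, and "the series" means these compounds.

Compound 1 `COC(=O)c1ccc(NCc2cncn2Cc2cccc(C)c2)cc1-c1ccccc1` was tested in a toxicity assay on NIH3T3 cells (Mus musculus) for cytotoxicity, read by resazurin assay; on this read-out higher numbers stand for an effect only at larger amounts of compound and lower numbers for an effect already at smaller amounts. In this assay compound 1 gives only a limit, > 10000 nM. Compound 2 `COC(=O)c1ccc(NCc2cncn2Cc2cccc(Cl)c2)cc1-c1ccccc1` carries chloro in place of methyl on an aromatic carbon; in this assay compound 2 likewise gives only a limit, > 10000 nM. Compound 3 `COC(=O)c1ccc(NCc2cncn2Cc2cccc(Br)c2)cc1-c1ccccc1` carries bromo in place of methyl on the same aromatic carbon, and in this assay compound 3 also returns only a limit, > 10000 nM. The three steps among these compounds, a step that the two limits leave unreadable from compound 1 to compound 2, a step that the two limits leave unreadable from compound 1 to compound 3 and a step that the two limits leave unreadable from compound 2 to compound 3, cannot be read in size or direction because of the limit of > 10000 nM in this assay, at which 3 of the 3 values shown sit.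

Compound 4 `COC(=O)c1ccc(NCc2cncn2Cc2ccc(F)cc2F)cc1-c1ccccc1` is not yet measured in this assay. Relative to compound 3 the change is 2,4-difluorophenyl in place of 3-bromophenyl on a saturated chain carbon bound to an aromatic nitrogen; cut one bond further out, it reads 3-bromobenzyl to 2,4-difluorobenzyl. For the measured compounds named here, no measured step bears on this change in a readable way: every value of compounds 1, 2 and 3 sits at the limit, so the only expectation available is that compound 4 stays in the same region. Compound 4 is therefore estimated at 20000 nM, with a range from 6000 nM to 60000 nM. The step from compound 3 to compound 4 is expected to be a step that the limit leaves unreadable from compound 3 to compound 4, most probably again reported as a limit rather than a number.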

Compound 4, half-maximal effective concentration: > 1000 nM
Compound 4: only a limit was reported (the forecaster's own chance of this, stated with the estimate: 80%); the middle value does not contradict the limit.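

Compound 4 gives only a limit in this assay, > 1000 nM. Its steps from compound 1, compound 2 and compound 3 cannot be read in size or direction because of the limit on its side: the limit of > 1000 nM in this assay, at which 1 of the 4 values shown sits.

The compounds shown leave open whether any of the four has a readable half-maximal effective concentration in this assay.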